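Methyl for bromo on the benzyl ring of a TRPV1 ligand

A few compounds are considered here, and "the series" means these few. Any claim that something is new, unique, unknown or untested is made for them only; others in the source may bear on it.

The series is followed in an assay on CHO cells for displacement of a labelled ligand from transient receptor potential cation channel subfamily V member 1 (Rattus norvegicus); on this read-out lower numbers stand for stronger inhibition and higher numbers for weaker inhibition. Compound 1 `CC(C)(C)c1ccc(CNC(=O)C(C)(C)c2ccc(NS(C)(=O)=O)c(F)c2)cc1` gives 1070 nM, and compound 2 `COc1cc(C2(C(=O)NCc3ccc(C(C)(C)C)cc3)CC2)ccc1NS(C)(=O)=O` gives 750 nM. Compound 3 `CC(C(=O)NCc1ccc(Br)cc1)c1ccc(NS(C)(=O)=O)c(F)c1` gives 412 nM; of the three numbers this is the lowest, yet the gap to compound 2 lies within the scatter, while the gap to compound 1 lies beyond it. Compound 3 therefore stands apart from compound 1 only.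

Compound 4 `Cc1ccc(CNC(=O)C(C)c2ccc(NS(C)(=O)=O)c(F)c2)cc1` is the next member, not yet measured in this assay. It differs from compound 3 in one place: methyl in place of bromo on an aromatic carbon. Cut one bond further out, the change reads 4-bromophenyl to 4-methylphenyl, or 4-bromobenzyl to 4-methylbenzyl.

Among the compounds with values here, no pair among the measured compounds shows this exchange, so the size of its effect cannot be read from the data. The account expects the methyl group to leave the inhibition constant close to that of compound 3, with a modest shift toward a higher number that may not exceed the scatter; the expected step is a 1.9-fold higher number from compound 3 to compound 4 (0.29 log units; within the scatter). On that basis the estimate for compound 4 in this assay is 800 nM, with a range from 300 nM to 2500 nM.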

Compound 4, inhibition constant: 3100 nM
For compound 4 the middle estimate is 3.9-fold (0.59 log units) below the measured one; the whole stated range lies below it.
By their numbers in this assay, from the lowest: compounds 3, 2 and 1 (each within the scatter of the next, the first and the last beyond it); then compound 4.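

Within the data shown here, the exchange of bromo for methyl on an aromatic carbon, para to a large group, is the first change in one place that the series offers, and in this assay it gives a 7.5-fold higher number from compound 3 to compound 4 (0.88 log units; beyond the scatter). The step lies beyond the scatter, so this position is not indifferent to what it carries. Bromo and methyl match in what can be counted here, with one heavy atom each, no hydrogen-bond donors or acceptors and no net charge, and yet the read-out tells them apart, so these counts alone do not settle the value at this place. Nothing at hand gives a reason for the difference between the two groups.

Compound 1 and compound 2 carry a tert-butyl group on the benzyl ring but differ from compound 3 in more than one place, so the compounds shown leave open what tert-butyl does at this position on the core of compound 3. On these data alone, it also remains open whether chloro, trifluoromethyl or methoxy here would give a value closer to that of compound 3 or to that of compound 4, and whether the bromo-to-methyl step keeps its size on the cores of compound 1 and compound 2.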